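From methylamino to methoxy on the shared core

A few compounds are considered here, and "the series" means these few. Any claim that something is new, unique, unknown or untested is made for them only; others in the source may bear on it.

Of the compounds shown here, three have numbers so far in a functional assay on MCF7 cells (Homo sapiens) for cytotoxicity, read by MTT assay, with a stated time of 72 h; on this read-out lower numbers stand for stronger inhibition and higher numbers for weaker inhibition. Compound 1 `Nc1cc2nc(-c3ccccc3)nn(-c3ccccc3)c-2cc1=O` gives 950 nM, compound 2 `CNc1cc2nc(-c3ccccc3)nn(-c3ccccc3)c-2cc1=O` gives 690 nM, and compound 3 `CCNc1cc2nc(-c3ccccc3)nn(-c3ccccc3)c-2cc1=O` gives 1620 nM.

Compound 2 stands within the scatter of compound 1, as a 1.4-fold lower number from compound 1 to compound 2 (0.14 log units; within the scatter) shows. Among the measured compounds shown here, its only step beyond the scatter is the modest 2.3-fold higher number from compound 2 to compound 3 (0.37 log units; beyond the scatter), while a 1.7-fold higher number from compound 1 to compound 3 (0.23 log units; within the scatter) stays within the scatter.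

Compound 4 `COc1cc2nc(-c3ccccc3)nn(-c3ccccc3)c-2cc1=O` is the next case: methoxy in place of methylamino on an aromatic carbon. In words, this is methoxy in place of methylamino on an aromatic carbon.

For the measured compounds named here, no measured step replaces the nitrogen on the aromatic ring, so all three bear on this change only indirectly. They alter the group on that nitrogen, and the largest of them is a 2.3-fold higher number from compound 2 to compound 3 (0.37 log units; beyond the scatter). The data hold no direct measure of exchanging methylamino for methoxy, so the range has to stay wide. On that limited basis, no step beyond the scatter is expected in this assay, and the estimate is placed among the three measured numbers.

The expected change is a 1.4-fold higher number from compound 2 to compound 4 (0.14 log units; within the scatter).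

For compound 4 the estimated value is 950 nM, with an expected range from 350 nM to 2600 nM.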

Compound 4, half-maximal inhibitory concentration: > 5000 nM
Compound 4 was reported as a limit; the forecaster's own chance of this, stated with the estimate: 3%; middle value at least 5.2-fold (0.72 log units) from the limit.
By their numbers in this assay, from the lowest: compounds 2, 1 and 3 (each within the scatter of the next, the first and the last beyond it). At a limit, above all of these: compound 4.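

The steps among compounds 1, 2 and 3 changed only the group on the nitrogen, and none went past modest; replacing that nitrogen-linked group with methoxy on the aromatic carbon gives a clearer separation in this assay, with an at least 7.2-fold higher number from compound 2 to compound 4 (0.86 log units; beyond the scatter). The same separation appears from the other two nitrogen-linked groups, with an at least 5.2-fold higher number from compound 1 to compound 4 (0.72 log units; beyond the scatter) and an at least 3.0-fold higher number from compound 3 to compound 4 (0.48 log units; beyond the scatter), so amino, methylamino and ethylamino all stand apart from methoxy at this position, even though the measured numbers for those three lie within a narrow span. Compound 4 is a limit and not a number, so these steps carry a floor but no measured size: the limit of > 5000 nM in this assay, at which 1 of the 4 values shown sits.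

The compounds shown do not separate the change from 1 hydrogen-bond donor to 0 from the exchange of nitrogen for oxygen itself, and a dimethylamino group or a hydroxyl group on this aromatic carbon would bear on that question. As far as these compounds go, how a longer chain on the nitrogen, such as propylamino, or a longer ether, such as ethoxy, would read at this position also stays open.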